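Hydrazide to pyrrolidine amide on the shared core

The source may hold more compounds than are shown below. What is called first, only, known or untested is meant among the compounds shown, and "the series" means these compounds.

Among the measured compounds shown here, compound 2 `NNC(=O)Cn1nc(N)c2c(C(F)(F)F)cc(-c3ccccc3)nc21` stands second highest of the three numbers so far in a functional assay on HeLa cells (Homo sapiens) for cytotoxicity, read by MTT assay, with a stated time of 24 h; a higher number here means a weaker inhibitor, a lower number a stronger inhibitor; compound 2 gives 48400 nM. Its nearest neighbour is compound 3 `Nc1nn(CC(=O)NCCO)c2nc(-c3ccccc3)cc(C(F)(F)F)c12`, which in this assay gives 69500 nM, the two lying a 1.4-fold higher number from compound 2 to compound 3 (0.16 log units; within the scatter). The furthest is compound 1 `CNC(=O)Cn1nc(N)c2c(C(F)(F)F)cc(-c3ccccc3)nc21`, which in this assay gives 12200 nM, the gap being a 4.0-fold higher number from compound 1 to compound 2 (0.60 log units; beyond the scatter).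

Compound 4 `Nc1nn(CC(=O)N2CCCC2)c2nc(-c3ccccc3)cc(C(F)(F)F)c12` is not yet measured. It differs from compound 2 as follows: pyrrolidin-1-yl in place of aminoamino on a carbonyl carbon.

For the measured compounds named here, no measured step covers this exact exchange. The steps that come nearest are a 4.0-fold higher number from compound 1 to compound 2 (0.60 log units; beyond the scatter), where amino replaces methyl on the amide-type nitrogen, and a 5.7-fold higher number from compound 1 to compound 3 (0.76 log units; beyond the scatter), where hydroxymethyl is added on the chain carbon bound to that nitrogen; both were modest and both moved the number up from compound 1. Compound 4, like compound 1, carries neither the amino nor the hydroxyl, so the step back towards compound 1 is the one expected here, but only at modest size.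

The estimate for compound 4 in this assay is 15000 nM, with a range from 5000 nM to 50000 nM, which means an expected step of a 3.2-fold lower number from compound 2 to compound 4 (0.51 log units; beyond the scatter).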

Compound 4, half-maximal inhibitory concentration: 16100 nM
For compound 4 the middle estimate is 1.1-fold (0.03 log units) below the measured one, and the stated range covers the measured number.
By their numbers in this assay, from the lowest: compounds 1 and 4 (each within the scatter of the next); then compounds 2 and 3 (each within the scatter of the next).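

Replacing the hydrazide end with the ring gives a 3.0-fold lower number from compound 2 to compound 4 (0.48 log units; beyond the scatter) in this assay and, against the hydroxyethyl amide, a 4.3-fold lower number from compound 3 to compound 4 (0.64 log units; beyond the scatter) on the same carbonyl carbon, so this position responds to the exchange of either open substituent for pyrrolidin-1-yl. Set against the small methylamino group, the ring gives a 1.3-fold higher number from compound 1 to compound 4 (0.12 log units; within the scatter) and the two cannot be told apart, which shows that the amide hydrogen kept by compound 1 is not required for a number at this level and that the five-membered ring, with its larger count of heavy atoms, costs nothing measurable here. Among these four compounds, the two without a terminal amino or hydroxyl group, compound 1 and compound 4, group together at the low end, none of the four goes against this, and nothing at hand accounts for the grouping.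

From the compounds shown here alone, whether the ring itself matters remains open, since a dimethylamino amide would separate ring closure from simple double substitution on the amide nitrogen, and a piperidine or morpholine amide would test ring size and a ring oxygen. A carboxylic acid at the same carbonyl carbon, or a longer chain ending in a methyl group, would show whether the terminal amino and hydroxyl groups or the chain length track with the higher numbers.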